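Ethyl to methyl on the aminoheterocycle across two cores

The source may hold more compounds than are shown below. What is called first, only, known or untested is meant among the compounds shown, and "the series" means these compounds.

Compound 3 `CCNc1nc(NCc2ccc(NC(=O)c3ccc(F)cc3)cc2Cl)c2ccccc2n1` and compound 2 `CNc1nc(NCc2ccc(NC(=O)c3ccc(F)cc3)cc2Cl)c2ccccc2n1` share one core. In a functional assay on HCT-116 cells (Homo sapiens) for inhibition, read by luminescence and resazurin assay, with a stated time of 3 days (a higher number here means a weaker inhibitor, a lower number a stronger inhibitor), compound 3 gives 1500 nM, and compound 2 gives 2000 nM. The change between them, (hydrogen in place of methyl on a saturated chain carbon bound to a nitrogen on an aromatic ring), made a 1.3-fold higher number from compound 3 to compound 2 (0.12 log units; within the scatter). Compound 1 `CCNc1ncc(C)c(NCc2ccc(NC(=O)c3ccc(F)cc3)cc2)n1` carries another core; the difference between the two cores is not broken down here. In this assay compound 1 gives only a limit, > 20000 nM. Compound 4 `CNc1ncc(C)c(NCc2ccc(NC(=O)c3ccc(F)cc3)cc2)n1` is not yet measured; it differs from compound 1 by hydrogen in place of methyl on a saturated chain carbon bound to a nitrogen on an aromatic ring, the same change as the measured one. The step from compound 1 to compound 4 is expected to be a step that the limit leaves unreadable from compound 1 to compound 4, as small as the measured step. That expectation rests on a 1.3-fold higher number from compound 3 to compound 2 (0.12 log units; within the scatter) and on (the limit of > 20000 nM in this assay, at which 1 of the 3 values shown sits). Compound 4 is therefore estimated at 30000 nM, most likely reported again as a limit only.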

Compound 4, half-maximal inhibitory concentration: > 20000 nM
Compound 4 ended at the assay's limit; the forecaster's own chance of this, stated with the estimate: 75%; the middle value lies beyond the limit too.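

Compound 1 and compound 4 both end at a limit, so no step between them can be read: the limit of > 20000 nM in this assay, at which 2 of the 4 values shown sit.

From the compounds shown here alone, whether ethyl to methyl has any effect on the core of compound 1 stays open, as neither compound gives a number.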